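Swapping a Fused Ring for Bromophenyl on the Core

The compounds below may be only part of what the source reports. "The series", "measured", "known", "first", "only" and "open" are said of these compounds alone.

Measured so far:
compound 1 `NCCCCn1c(SCCc2c[nH]c3ccccc23)nnc1-c1cnc2ccccc2n1`: 32 nM
compound 2 `NCCCn1c(SCCc2c[nH]c3ccccc23)nnc1-c1ccc2ccccc2c1`: 640 nM
compound 3 `NCCCCn1c(SCCc2c[nH]c3ccc(Cl)cc23)nnc1-c1ccc2ccccc2n1`: 5.6 nM

Of the compounds shown here, three sharing one core have been tested. In an assay on isolated protein for inhibition of somatostatin receptor type 2 (Homo sapiens), tested at 10 uM (on this read-out higher numbers stand for weaker inhibition and lower numbers for stronger inhibition), compound 1 gives 32 nM. Compound 3 gives 5.6 nM, a lower number beyond the scatter, while compound 2 gives 640 nM, a higher number beyond the scatter. Compound 1 therefore stands second highest of the three, closer to compound 3 than to compound 2.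

Compound 4 `NCCCCn1c(SCCc2c[nH]c3ccccc23)nnc1-c1cccc(Br)c1` has not been measured. It differs from compound 1 in one place: 3-bromophenyl in place of quinoxalin-2-yl on an aromatic carbon. For the measured compounds named here, no pair of measured compounds differs in only one place, so no measured step guides this change directly. Still, the smaller single ring replacing the fused ring with two acceptors is expected to raise the number in this assay beyond the scatter. Compound 4 is expected to give 250 nM in this assay, with a range from 60 nM to 1200 nM. The expected step of a 7.8-fold higher number from compound 1 to compound 4 (0.89 log units; beyond the scatter) is estimated as a clear loss of inhibition.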

Compound 4, inhibition constant: 250 nM
The estimate for compound 4 equals the measured number at the digits printed, within the range that was stated.
By their numbers in this assay, from the lowest: compound 3; then compound 1; then compound 4; then compound 2.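

For the compounds shown here, this is the first change that can be read at a single place. In this assay putting 3-bromophenyl in place of quinoxalin-2-yl on the aromatic carbon of the shared core gives a 7.8-fold higher number from compound 1 to compound 4 (0.89 log units; beyond the scatter) as a step beyond the scatter. The position is therefore sensitive to what it carries: the read-out moves when a group with two aromatic rings and two hydrogen-bond acceptors gives way to one with a single carbon-only aromatic ring, no acceptors and a bromine. No supporting measurement is available to explain this step.

Because these features all change together, the compounds shown cannot separate their contributions. A plain phenyl, 3-chlorophenyl or pyridin-2-yl group at this carbon would help show which feature matters.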